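This account rests on a few compounds, and the source may have more. Where it says the series, first, only, none or still open, it means among the compounds named here.

Three small molecules have been tested in a functional assay on HeLa cells (Homo sapiens), with a stated time of 3 days; a higher number here means a weaker inhibitor, a lower number a stronger inhibitor. Compound 1 `O=C1C=CCO[C@@H]1n1ccc(O)nc1=O` gives 42000 nM, and compound 2 `C=C1C=CCO[C@@H]1n1cc(C)c(O)nc1=O` gives 339000 nM. Compound 3 `C=C1C=CCO[C@@H]1n1ccc(N)nc1=O` gives 990000 nM, the highest number of the three, which makes it the weakest inhibitor in the set. Its gap to each of the other two lies beyond the usual scatter of repeat measurements, and it is wider to compound 1 than to compound 2.

The next molecule, compound 4 `C=C1C=CCO[C@@H]1n1ccc(O)nc1=O`, changes compound 3 in a single place, with hydroxy in place of amino on an aromatic carbon.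

For the measured compounds named here, no measured pair shows this swap on its own, so its size cannot be read directly from the data. Going by the values given here, the only guide is that compound 1, at 42000 nM, and compound 2, at 339000 nM, both carry hydroxy at this place and both have lower numbers than compound 3. Neither is an exact match for compound 4, so this guide is a loose one. A moderate move towards stronger inhibition therefore seems likely, rather than a large one.

The expected change is a 3.3-fold lower number from compound 3 to compound 4 (0.52 log units; beyond the scatter).

For compound 4, the estimated value in this assay is 300000 nM, with an expected range from 100000 nM to 900000 nM.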

Compound 4, half-maximal inhibitory concentration: 760000 nM
Estimate against measurement, compound 4: 2.5-fold (0.40 log units) below; the measured number falls inside the stated range.
By their numbers in this assay, from the lowest: compound 1; then compound 2; then compounds 4 and 3 (each within the scatter of the next).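

The swap of amino for hydroxy, on the aromatic carbon next to the ring nitrogen, now has a direct reading in this assay: it gives a 1.3-fold lower number from compound 3 to compound 4 (0.11 log units; within the scatter) and stays within the usual scatter of repeat measurements. On this core, then, the two groups cannot be told apart at this position, and hydroxy alone brings no measurable gain in this assay. The other single change, hydrogen in place of methyl on an aromatic carbon, gives a 2.2-fold higher number from compound 2 to compound 4 (0.35 log units; beyond the scatter) in this assay, a modest step but one beyond the scatter, so the methyl-bearing compound 2 is the stronger inhibitor of that pair. No supporting measurement is available to explain either result.

The compounds shown leave open whether a methoxy group or a chlorine atom at the amino and hydroxy position would give a different number from these two groups. They also leave open whether an ethyl group in place of the methyl would extend the modest step seen with methyl or reverse it.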